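Chain extension of the hydroxyalkyl carbonate series

The source may hold more compounds than are shown below. What is called first, only, known or untested is meant among the compounds shown, and "the series" means these compounds.

In an ADME assay for pharmacokinetics (on this read-out lower numbers stand for a shorter-lived compound and higher numbers for a longer-lived compound), compound 1 `Cc1cn(C2CC(N=[N+]=[N-])C(COC(=O)OCCO)O2)c(=O)[nH]c1=O` gives only a limit of the assay, < 0.0167 h. Compound 2 `Cc1cn(C2CC(N=[N+]=[N-])C(COC(=O)OCCCCO)O2)c(=O)[nH]c1=O` gives 0.5 h, and compound 3 `Cc1cn(C2CC(N=[N+]=[N-])C(COC(=O)OCCCCCO)O2)c(=O)[nH]c1=O` gives 0.267 h, the lowest of the two numbers, with the gap to compound 2 within the scatter. Compound 4 `Cc1cn(C2CC(N=[N+]=[N-])C(COC(=O)OCCCCCCO)O2)c(=O)[nH]c1=O` is not yet measured; it differs from compound 3 by hydroxymethyl in place of hydroxy on a saturated chain carbon, five bonds along the chain from an oxygen next to a carbonyl group. The closest measured step is of the same kind, one bond shorter: a 1.9-fold lower number from compound 2 to compound 3 (0.27 log units; within the scatter). The large steps of an at least 29-fold higher number from compound 1 to compound 2 (1.47 log units; beyond the scatter) and an at least 15-fold higher number from compound 1 to compound 3 (1.20 log units; beyond the scatter) rest on a limit of < 0.0167 h in this assay, at which 1 of the 3 values shown sits, and give no scale for a further extension. A step within the scatter is therefore expected, a 1.1-fold lower number from compound 3 to compound 4 (0.03 log units; within the scatter). Compound 4 is expected to give 0.25 h in this assay, between 0.1 h and 0.6 h.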

Compound 4, half-life in the ADME assay: 0.117 h
The estimate for compound 4 lay 2.1-fold (0.33 log units) above the measured number; measured number inside the range.
By their numbers in the ADME assay, from the lowest: compound 4; then compounds 3 and 2 (each within the scatter of the next). At a limit, below all of these: compound 1.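

At this position, five bonds along the chain from an oxygen next to a carbonyl group, hydroxymethyl in place of hydroxy gives a step beyond the scatter in the ADME assay: a 2.3-fold lower number from compound 3 to compound 4 (0.36 log units; beyond the scatter). In the ADME assay the step one bond shorter stays within the scatter: a 1.9-fold lower number from compound 2 to compound 3 (0.27 log units; within the scatter). Across both extensions, the ADME assay shows a 4.3-fold lower number from compound 2 to compound 4 (0.63 log units; beyond the scatter). In a physicochemical assay for lipophilicity (a higher number here means a more lipophilic compound, a lower number a more polar compound), compound 3 gives 0.45 and compound 4 gives 0.08. In the physicochemical assay the same change gives a number 0.37 log units lower from compound 3 to compound 4 (beyond the scatter). In the ADME assay compound 1 gives < 0.0167 h, which is a limit. Measured against that limit, the ADME assay shows an at least 7.0-fold higher number from compound 1 to compound 4 (0.84 log units; beyond the scatter), so the exact size of this step cannot be read.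

As far as these compounds go, whether a longer chain continues this downward run stays open. So does how an amine or a carboxylic acid in place of hydroxy would read.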